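Swapping a carbamate ester group for a difluoroethyl ketone

The compounds below may be only part of what the source reports. "The series", "measured", "known", "first", "only" and "open" are said of these compounds alone.

Of the compounds shown here, three sharing one core have been measured in a functional assay on isolated protein for inhibition of Glucose-dependent insulinotropic receptor (Homo sapiens), read by HTRF and cAMP accumulation; a lower number here means that less compound is needed, a higher number that more compound is needed for the effect. Compound 1 `Cc1nc(S(C)(=O)=O)ccc1Oc1ncnc(OC2CCN(C(=O)OC3CCC3)CC2)c1F` gives 13.6 nM, compound 2 `Cc1nc(S(C)(=O)=O)ccc1Oc1ncnc(OC2CCN(C(=O)O[C@@H](C)C(F)(F)F)CC2)c1F` gives 9.86 nM, and compound 3 `Cc1nc(S(C)(=O)=O)ccc1Oc1ncnc(OC2CCN(C(=O)OC3(C(F)(F)F)CCC3)CC2)c1F` gives 14.3 nM. Compound 3 stands highest of the three numbers, but the steps leading to it are a 1.1-fold higher number from compound 1 to compound 3 (0.02 log units; within the scatter) and a 1.5-fold higher number from compound 2 to compound 3 (0.16 log units; within the scatter), so the three values cannot be told apart; the step of a 1.4-fold lower number from compound 1 to compound 2 (0.14 log units; within the scatter) is likewise within the scatter.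

Compound 4 `Cc1nc(S(C)(=O)=O)ccc1Oc1ncnc(OC2CCN(C(=O)C(C)(F)F)CC2)c1F` differs from compound 3 in this way: a group of 4 heavy atoms (2 carbon, 2 fluorine; no ring) in place of a group of 9 heavy atoms (5 carbon, 1 oxygen, 3 fluorine; one four-membered non-aromatic ring of carbon only), on a carbonyl carbon. Every measured step concerns only the group on the oxygen of the carbamate, whereas here the oxygen-bearing group itself is removed and a 1,1-difluoroethyl sits directly on the carbonyl carbon. For the measured compounds named here, no measured step therefore bears on this change, and the expectation rests on the observation that the three measured values of compounds 1, 2 and 3 all lie close together. Compound 4 is expected to give about 20 nM, between 7 nM and 60 nM, which corresponds to an expected step of a 1.4-fold higher number from compound 3 to compound 4 (0.15 log units; within the scatter).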

Compound 4, half-maximal effective concentration: 37 nM
Compound 4: the middle estimate sits 1.9-fold (0.27 log units) below what was measured, within the range that was stated.
By their numbers in this assay, from the lowest: compounds 2, 1 and 3 (each within the scatter of the next); then compound 4.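

Compound 4 is the only compound shown with no oxygen between the carbonyl carbon and its group, and the 1,1-difluoroethyl there gives the first change in this series that lies beyond the scatter in this assay (a 2.6-fold higher number from compound 3 to compound 4 (0.41 log units; beyond the scatter)). The other two steps to it point the same way (a 2.7-fold higher number from compound 1 to compound 4 (0.43 log units; beyond the scatter); a 3.8-fold higher number from compound 2 to compound 4 (0.57 log units; beyond the scatter)), so the number rises from all three carbamates, which could not be told apart from one another, and none of them goes against this, though each step remains modest. No measurement given here accounts for the rise.

The compounds shown do not separate the loss of the oxygen from the identity of the 1,1-difluoroethyl itself. Going by these compounds, a cyclobutyl or a plain ethyl chain, or an amine, on the carbonyl carbon remains open, as does any change elsewhere on the shared core.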